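The compounds below may be only part of what the source reports. "The series", "measured", "known", "first", "only" and "open" are said of these compounds alone.

In a toxicity assay on NIH3T3 cells (Mus musculus) for cytotoxicity, read by resazurin assay (a lower number here means that less compound is needed, a higher number that more compound is needed for the effect), compound 1 (`CN(C)c1ccc(NCc2cncn2Cc2ccc(-c3ccccc3)cc2)cc1-c1ccccc1`) gives > 1000 nM, which is a limit and not a number. Compound 2 (`COC(=O)c1ccc(NCc2cncn2Cc2ccc(N)cc2)cc1-c1ccccc1`) also gives only a limit, > 10000 nM. Compound 1 therefore has no measured concentration to set against compound 2. Compound 3 (`c1ccc(-c2ccc(Cn3cncc3CNc3ccc(-c4ccccc4)c(-c4ccccc4)c3)cc2)cc1`) has yet to be measured in this assay. It carries phenyl in place of dimethylamino on an aromatic carbon, ortho to a phenyl group: phenyl in place of dimethylamino on an aromatic carbon. For the measured compounds named here, no measured step bears on this change. Going by the values given here, the only anchor is compound 1, whose > 1000 nM is a limit, so a modest move toward a higher number is expected in this assay, though one within the scatter would be no surprise. The expected step is a step that the limit leaves unreadable from compound 1 to compound 3. The estimated value for compound 3 is 3000 nM, with an expected range of 800 nM to 12000 nM.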

Compound 3, half-maximal effective concentration: > 10000 nM
Compound 3 ended at the assay's limit (the forecaster's own chance of this, stated with the estimate: 60%); middle value at least 3.3-fold (0.52 log units) from the limit.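

In this assay, for the compounds shown here, compound 1 and compound 3 both end at limits and not at numbers; no step between them can be read. From the compounds shown here alone, whether phenyl in place of dimethylamino changes the concentration needed for the effect, and in which direction, stays open.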